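Swapping Phenoxy for Cyclopropyl on a Second Core

The source may report more compounds than this note shows. Statements on the series, on what has been measured and on what is new or still open speak of the compounds shown alone.

Compound 1 `COc1ccc(C2C(Oc3ccccc3)C(=O)N2c2cc(OC)c(OC)c(OC)c2)cc1`: 52 nM
Compound 2 `COc1ccc(C2C(C3CC3)C(=O)N2c2cc(OC)c(OC)c(OC)c2)cc1`: 107 nM
Compound 3 `COc1cc(N2C(=O)C(Oc3ccccc3)C2c2ccc(SC)cc2)cc(OC)c1OC`: 336 nM

All three were tested in a functional assay on HT-29 cells (Homo sapiens) for inhibition, read by sulforhodamine B assay, with a stated time of 72 h; a higher number here means a weaker inhibitor, a lower number a stronger inhibitor. Compound 1 and compound 2 share a core and differ in one place: cyclopropyl in place of phenoxy on a saturated ring carbon. That exchange gave a 2.1-fold higher number from compound 1 to compound 2 (0.31 log units; beyond the scatter), a modest loss that lies beyond the usual scatter. Compound 3 carries a second core, which differs from the core of compound 1 in one place: methylsulfanyl in place of methoxy on an aromatic carbon. That exchange gave a 6.5-fold higher number from compound 1 to compound 3 (0.81 log units; beyond the scatter), and compound 3 shows the highest number of the three measured compounds.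

Compound 4 `COc1cc(N2C(=O)C(C3CC3)C2c2ccc(SC)cc2)cc(OC)c1OC` has not yet been measured. It stands to compound 3 as compound 2 stands to compound 1: cyclopropyl in place of phenoxy on a saturated ring carbon. The two exchanges are the same kind of change rather than the same change, since the surroundings differ: in compound 1 the altered carbon is next to the ring atom that bears a 4-methoxyphenyl group, whereas in compound 3 it is next to the ring atom that bears a 4-(methylsulfanyl)phenyl group. Only one earlier example of this exchange exists among these compounds, so the expectation rests on it alone. Compound 4 is expected to show a 2.1-fold higher number from compound 3 to compound 4 (0.32 log units; beyond the scatter) because the same exchange on the first core gave a 2.1-fold higher number from compound 1 to compound 2 (0.31 log units; beyond the scatter). In this assay compound 4 is therefore estimated at 700 nM, most likely between 300 nM and 1600 nM.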

Compound 4, half-maximal inhibitory concentration: 204 nM
Estimate against measurement, compound 4: 3.4-fold (0.54 log units) above; measured number below the stated range.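

In this assay, the phenoxy-to-cyclopropyl exchange on the second core gave a 1.6-fold lower number from compound 3 to compound 4 (0.22 log units; within the scatter), so compound 3 and compound 4 cannot be told apart, and the clear loss seen with this exchange on the first core did not carry over: the same change on two cores in this assay, a 2.1-fold higher number (0.31 log units; beyond the scatter) from compound 1 to compound 2 and a 1.6-fold lower number (0.22 log units; within the scatter) from compound 3 to compound 4, 3.4-fold (0.53 log units) apart, beyond the scatter of two such steps. Read the other way, methylsulfanyl in place of methoxy gave a 1.9-fold higher number from compound 2 to compound 4 (0.28 log units; within the scatter), also too small to separate the two compounds, and this differs from the larger step seen when phenoxy occupies the saturated ring carbon: the same change on two cores in this assay, a 6.5-fold higher number (0.81 log units; beyond the scatter) from compound 1 to compound 3 and a 1.9-fold higher number (0.28 log units; within the scatter) from compound 2 to compound 4, 3.4-fold (0.53 log units) apart, beyond the scatter of two such steps. Among these compounds, in these four compounds, then, the effect of each change depends on the group at the other place, but with only one pair per core for each change, this does not show why they interact or which result would be typical of the wider series.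

The compounds shown leave open whether other groups on the saturated ring carbon, such as an amine or a longer carbon chain, would follow the result on the first core or the one on the second. They also leave open whether a chlorine atom or an ethoxy group in place of the methoxy or methylsulfanyl group would show the same dependence.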